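Series notes: aryl tail exchange on the shared acid core

The source may hold more compounds than are shown below. What is called first, only, known or untested is meant among the compounds shown, and "the series" means these compounds.

Measured so far:
compound 1, `Cc1cc(COc2ccc3c(c2)OCC3CC(=O)O)nn1-c1ccccc1`, 0.98%
compound 2, `Cc1nc(-c2cc3ccccc3o2)sc1COc1ccc2c(c1)OCC2CC(=O)O`, 14.8%

Two compounds of the series have been run in a functional assay on CHO cells for agonist activity at Free fatty acid receptor 1 (Homo sapiens), read by FLIPR and calcium flux, tested at 100 nM; a lower number here means a weaker effect, a higher number a stronger effect of the compound at the concentration tested. Compound 1 gives 0.98% in this assay, and compound 2 gives 14.8%. Compound 2 thus stands highest of the two numbers, and its distance to compound 1 lies beyond the scatter of the measurement.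

The next compound, compound 3, is `Cc1nc(-c2ccc(C(F)(F)F)cc2)sc1COc1ccc2c(c1)OCC2CC(=O)O`. It differs from compound 2 in one place: 4-(trifluoromethyl)phenyl in place of 1-benzofuran-2-yl on an aromatic carbon. The change sits on an aromatic carbon of the five-membered aromatic ring with 1 nitrogen and 1 sulfur, and the rest of the molecule, including the acid core, is kept.

Among the compounds with values here, no step between two measured compounds bears on this exchange, so the two values above give no direct guide. The expectation for compound 3 is a step of a number 5.2 percentage points higher from compound 2 to compound 3 (within the scatter) in this assay, most likely within the scatter or modestly upward. Compound 3 is therefore estimated at 20%, with a range from 3% to 50%.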

Compound 3, a percentage reported as activity, at one concentration (the size of the read-out at that concentration, not a potency): 50.4%
Beside the measured number, compound 3's estimate is 30.4 percentage points below it; measured number above the stated range.
By their numbers in this assay, from the lowest: compound 1; then compound 2; then compound 3.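

In this assay, the aromatic carbon of the five-membered aromatic ring with 1 nitrogen and 1 sulfur proves sensitive to the choice of aryl group: 4-(trifluoromethyl)phenyl in place of 1-benzofuran-2-yl gives a number 35.6 percentage points higher from compound 2 to compound 3 (beyond the scatter). The group that leaves holds two aromatic rings and one hydrogen-bond acceptor, whereas the group that enters holds one aromatic ring and no hydrogen-bond acceptor, so within this pair the higher read-out at the tested concentration requires neither the five-membered ring of the leaving group nor its oxygen. No measurement at hand accounts for the size of this step.

The pair changes the ring count and introduces trifluoromethyl in a single exchange, leaving open which of the two changes carries the step; an unsubstituted phenyl, or the same phenyl bearing a methoxy group or a nitrile, would separate them. Also open, on these data alone, is whether the step holds when the methyl group two ring bonds from this position gives way to hydrogen or a longer chain.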